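Compound 3: a methylene added to a low-stability lead

A few compounds are considered here, and "the series" means these few. Any claim that something is new, unique, unknown or untested is made for them only; others in the source may bear on it.

Measured so far in an ADME assay on S9 fraction from liver (Rattus norvegicus) for metabolic stability, with a stated time of 1 h; a higher number here means that more of the compound is left, a lower number that less of the compound is left 
- compound 1 `N#Cc1cnc(NCc2cnccc2C(F)(F)F)cc1N[C@H]1CC[C@@H](O)CC1` gives 6% 
- compound 2 `N#Cc1cnc(NCc2ccccc2C(F)(F)F)cc1N[C@H]1CC[C@@H](O)CC1` gives 31% 

Compound 1 is the lower of the two, and its gap to compound 2 lies beyond the scatter. Little of compound 1 is left at the end of the incubation. The next compound to read is compound 3 `N#Cc1cnc(NCc2cnccc2C(F)(F)F)cc1NC[C@H]1CC[C@H](O)CC1`, which has no number yet. Its change from compound 1 is (4-hydroxycyclohexyl)methyl in place of 4-hydroxycyclohexyl on a nitrogen on an aromatic ring. The same difference can be read as (4-hydroxycyclohexyl)amino to ((4-hydroxycyclohexyl)methyl)amino. Among the measured compounds shown here, no measured pair shows this change, so the size of the step remains uncertain. A small upward step, not beyond the scatter, is expected because compound 1 stands at 6% and has little room to fall. The estimated move runs a number 4 percentage points higher from compound 1 to compound 3 (within the scatter). For compound 3 the expected value is 10%, with an estimated range of 3% to 25%.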

Compound 3, percent of the compound remaining: 6%
For compound 3 the middle estimate is 4 percentage points above the measured one; the measured number falls inside the stated range.
By their numbers in this assay, from the lowest: compounds 1 and 3 (each within the scatter of the next); then compound 2.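

In this assay, among the compounds shown here, the change from 4-hydroxycyclohexyl to (4-hydroxycyclohexyl)methyl on a nitrogen on an aromatic ring reads no change at the digits printed from compound 1 to compound 3 (within the scatter) and gives the first direct look at this position. On the core of compound 1, this one-carbon extension does not lift the compound out of the low range, and little of either compound is left at the end of the incubation. Nothing available bears on why the read-out stays where it does.

Still open, going by these compounds, is whether the same extension would leave the read-out unchanged on the core of compound 2, where more of the compound remains. Also open, on these data alone, is whether a longer chain such as (4-hydroxycyclohexyl)ethyl, or an amine or a carboxylic acid in place of the hydroxyl, would move the number at this nitrogen.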